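Benzoyl in place of (((tert-butoxycarbonyl)amino)methyl)carbonyl

A few compounds are considered here, and "the series" means these few. Any claim that something is new, unique, unknown or untested is made for them only; others in the source may bear on it.

Compound 1 `COc1ccc(N(CC(=O)NCCC[Te]c2ccccc2)C(=O)CNC(=O)OC(C)(C)C)cc1` carries a tellurium-bearing side chain on the shared core. In a functional assay on OVCAR-4 cells (Homo sapiens) for inhibition, with a stated time of 48 h (a lower number here means a stronger inhibitor of growth, a higher number a weaker inhibitor of growth), compound 1 returns only a limit, < 100000 nM, so its standing is not a number. Compound 2 `COc1ccc(N(CC(=O)NCCC[Te]c2ccccc2)C(=O)CCSC2=C(C)C(=O)c3ccccc3C2=O)cc1` extends the same core with a quinone-bearing chain. In this assay compound 2 gives 10200 nM. Within the data shown here, no two measured compounds differ in a single place, so no measured step exists; the only evidence is the limit of < 100000 nM in this assay, at which 1 of the 2 values shown sits.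

Compound 3 `COc1ccc(N(CC(=O)NCCC[Te]c2ccccc2)C(=O)c2ccccc2)cc1` changes compound 1 in one place: phenyl in place of ((tert-butoxycarbonyl)amino)methyl on a carbonyl carbon. The amide-type nitrogen and the remainder of the core stay as they are. With compound 1 at a limit, the step size cannot be read from a measured pair. A modest shift towards stronger growth inhibition is expected from compound 1 to compound 3 a step that the limit leaves unreadable from compound 1 to compound 3. Compound 3 is expected to give 20000 nM, with a range from 5000 nM to 80000 nM.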

Compound 3, concentration for total growth inhibition: 25100 nM
For compound 3 the middle estimate is 1.3-fold (0.10 log units) below the measured one; the range from low to high includes it.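

In this assay, among these compounds, compound 1 gives only a limit and not a number, so no step to compound 3 can be read: the limit of < 100000 nM in this assay, at which 1 of the 3 values shown sits.

The compounds shown leave open how large a change in growth inhibition follows when phenyl replaces ((tert-butoxycarbonyl)amino)methyl on a carbonyl carbon.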